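Replacing Bromo with Methoxy: An Expected Cytotoxicity Value

The compounds below may be only part of what the source reports. "The series", "measured", "known", "first", "only" and "open" are said of these compounds alone.

Of the compounds shown here, three have so far been measured in an ADME assay on THP-1 cells (Homo sapiens) for cytotoxicity, read by MTT assay, tested at 50 ug/mL; on this read-out lower numbers stand for less inhibition and higher numbers for more inhibition at the one concentration tested (going by the name of the read-out). Compound 1 `Brc1ccc(-c2csc(N/N=C/c3ccc(-n4ccnc4)cc3)n2)cc1` gives 36.8%, compound 2 `C(=N/Nc1nc(-c2ccccc2)cs1)\c1ccc(-n2cncn2)cc1` gives 28.4%, and compound 3 `Brc1ccc(-c2csc(N/N=C/c3ccc(-n4cncn4)cc3)n2)cc1` gives 32.6%. Compound 3 thus stands second highest of the three numbers, yet both of the measured steps that reach it lie within the scatter: a number 4.2 percentage points lower from compound 1 to compound 3 (within the scatter) and a number 4.2 percentage points higher from compound 2 to compound 3 (within the scatter).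

The unmeasured compound 4 `COc1ccc(-c2csc(N/N=C/c3ccc(-n4cncn4)cc3)n2)cc1` differs from compound 3 in a single place, (methoxy in place of bromo on an aromatic carbon). Among the measured compounds shown here, of the measured steps, only the one from compound 2 to compound 3 concerns the same aromatic carbon, and it exchanged hydrogen for bromo rather than bromo for methoxy; it was small and within the scatter. The other step touched a different part of the shared core and was likewise within the scatter. For the measured compounds named here, no measured step therefore speaks directly to a methoxy group, and nothing in the data points to a move beyond the scatter in this assay.

Compound 4 is accordingly expected to give 31%, with a range from 18% to 44%, the expected step being a number 1.6 percentage points lower from compound 3 to compound 4 (within the scatter).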

Compound 4, a percentage reported as inhibition, at one concentration (the size of the read-out at that concentration, not a potency): 23%
Compound 4: the middle estimate sits 8 percentage points above what was measured, within the range that was stated.
By their numbers in this assay, from the lowest: compounds 4, 2, 3 and 1 (each within the scatter of the next, the first and the last beyond it).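

In this assay the methoxy group gives a number 9.6 percentage points lower from compound 3 to compound 4 (within the scatter) and, measured against the unsubstituted phenyl, a number 5.4 percentage points lower from compound 2 to compound 4 (within the scatter) as well, so both steps stay within the scatter. Together with the earlier exchange of hydrogen for bromo, this means that hydrogen, bromo and methoxy have now all been read on this aromatic carbon, para to a large group, with the 1H-1,2,4-triazol-1-yl group held in place, and no step among them is printed as beyond the scatter; even the change from 4-bromophenyl to 4-methoxyphenyl, which brings in a hydrogen-bond acceptor, does not separate the two compounds on this read-out. Nothing available accounts for the size or direction of these small steps.

The compounds shown leave open whether an amine or a carboxylic acid on this same carbon would give a step beyond the scatter. They also leave open whether methoxy would read the same with the 1H-imidazol-1-yl group of compound 1 in place of the 1H-1,2,4-triazol-1-yl group.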